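Sulfonamide series: a second methyl on the aniline ring

The compounds below may be only part of what the source reports. "The series", "measured", "known", "first", "only" and "open" are said of these compounds alone.

Measured so far:
compound 1 `COc1cccc(NS(=O)(=O)c2ccc(N3CCNC3=O)cc2)c1` — 730 nM
compound 2 `Cc1cccc(NS(=O)(=O)c2ccc(N3CCNC3=O)cc2)c1` — 1270 nM

In a functional assay on MDA-MB-231 cells (Homo sapiens) for antiproliferative activity, read by sulforhodamine B assay, with a stated time of 48 h (a lower number here means a stronger inhibitor, a higher number a weaker inhibitor), compound 1 gives 730 nM and compound 2 gives 1270 nM. Compound 2 has the highest of the two numbers, but its nearest neighbour is compound 1, and the difference a 1.7-fold higher number from compound 1 to compound 2 (0.24 log units; within the scatter) stays within the scatter, so the two compounds cannot be ordered on these data.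

Compound 3 `Cc1ccc(C)c(NS(=O)(=O)c2ccc(N3CCNC3=O)cc2)c1` is not yet measured. It differs from compound 2 by methyl in place of hydrogen on an aromatic carbon; cut one bond further out, the change reads 3-methylphenyl to 2,5-dimethylphenyl.

Within the data shown here, the one measured step, a 1.7-fold higher number from compound 1 to compound 2 (0.24 log units; within the scatter), concerns a different exchange on the same ring and bears on this one only loosely; no step adding a methyl in place of hydrogen exists. Taken as the sole guide, it suggests a small shift at most. For compound 3 the step of a 1.1-fold higher number from compound 2 to compound 3 (0.04 log units; within the scatter) is therefore expected to remain within the scatter, and compound 3 is estimated at 1400 nM, with a range from 600 nM to 3500 nM.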

Compound 3, half-maximal inhibitory concentration: 110 nM
The estimate for compound 3 lay 13-fold (1.10 log units) above the measured number, and the stated range ends above it.
By their numbers in this assay, from the lowest: compound 3; then compounds 1 and 2 (each within the scatter of the next).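

In this assay, among these compounds, methyl in place of hydrogen on this aromatic carbon, ortho to a large group and para to a methyl group, gives a 12-fold lower number from compound 2 to compound 3 (1.06 log units; beyond the scatter) and is the first step to lie beyond the scatter, so this position is sensitive to a single added carbon. Read as one exchange on the sulfonamide nitrogen, 2,5-dimethylphenyl in place of 3-methoxyphenyl gives a 6.6-fold lower number from compound 1 to compound 3 (0.82 log units; beyond the scatter), so compound 3 has the lowest number of the three, with both of its steps beyond the scatter, whereas the earlier exchange of methoxy for methyl gave only a 1.7-fold higher number from compound 1 to compound 2 (0.24 log units; within the scatter) and left the two compounds unordered. No accompanying measurement bears on why a single methyl carries a step of this size.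

The compounds shown leave open whether this step depends on the methyl group already standing para to the new one or would also appear with that methyl absent. They also leave open whether the carbon tolerates anything other than methyl, such as an ethyl group, a chlorine atom or an amine.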